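Chain terminus variation in a fatty-acid amide hydrolase series

This account rests on a few compounds, and the source may have more. Where it says the series, first, only, none or still open, it means among the compounds named here.

Measured compounds:
compound 1 `COC(=O)c1ccc(-c2cnc(C(=O)CCCCCCc3ccccc3)o2)nc1` — 3.1 nM
compound 2 `COC(=O)CCCCc1cnc(C(=O)CCCCCCc2ccccc2)o1` — 1.8 nM
compound 3 `O=CCCCCc1cnc(C(=O)CCCCCCc2ccccc2)o1` — 14.6 nM

In an assay for inhibition of Fatty-acid amide hydrolase 1 (Rattus norvegicus), using a Dixon plot (on this read-out lower numbers stand for stronger inhibition and higher numbers for weaker inhibition), compound 3 gives 14.6 nM, the highest number of the three measured. Compound 1 gives 3.1 nM and compound 2 gives 1.8 nM. Among the measured compounds shown here, the single one-place step among the measured compounds is an 8.1-fold higher number from compound 2 to compound 3 (0.91 log units; beyond the scatter), which shows that the group at the end of the chain moves this assay by a clear margin.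

Compound 4 `CSCCCCCc1cnc(C(=O)CCCCCCc2ccccc2)o1` differs from compound 3 by (methylsulfanyl)methyl in place of formyl on a saturated chain carbon, four bonds along the chain from an aromatic carbon. For the measured compounds named here, no measured step introduces a (methylsulfanyl)methyl group, so the step from compound 2 to compound 3 bears on it only in showing that the chain terminus matters; it gives no direction for the present change. Because compound 3 already stands at 14.6 nM and the methoxy-bearing compound 2 sits at 1.8 nM, the expected number for compound 4 lies between those two. The step is estimated as a 2.4-fold lower number from compound 3 to compound 4 (0.39 log units; beyond the scatter). Compound 4 is expected to give 6 nM, within a range of 1.5 nM to 25 nM.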

Compound 4, inhibition constant: 8.1 nM
Estimate against measurement, compound 4: 1.4-fold (0.13 log units) below; the measured number falls inside the stated range.
By their numbers in this assay, from the lowest: compounds 2 and 1 (each within the scatter of the next); then compounds 4 and 3 (each within the scatter of the next).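

In this assay the formyl and (methylsulfanyl)methyl termini cannot be told apart at this position, on a saturated chain carbon, four bonds along the chain from an aromatic carbon (a 1.8-fold lower number from compound 3 to compound 4 (0.26 log units; within the scatter)). The methoxycarbonyl terminus of compound 2 now stands apart from two different replacements rather than one, since the step to the thioether is also beyond the scatter (a 4.5-fold higher number from compound 2 to compound 4 (0.65 log units; beyond the scatter)). No supporting data bear on why these termini compare as they do.

The compounds shown leave open whether the lower number of compound 2 belongs to the methyl ester specifically or would carry over to a carboxylic acid or a primary amide at the same terminus. Going by these compounds, how a longer or shorter chain bearing the methoxycarbonyl group would read also remains open.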